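This account rests on a few compounds, and the source may have more. Where it says the series, first, only, none or still open, it means among the compounds named here.

Measured so far in a functional assay (Homo sapiens) for inhibition of Nucleic Acid, tested at 100 uM; on this read-out higher numbers stand for more inhibition at the one concentration tested (going by the name of the read-out) and lower numbers for less inhibition: compound 1 `OC[C@H]1O[C@@H](n2cnc3c(NCc4ccccc4)nccc32)C[C@@H]1O` gives 15%; compound 2 `OC[C@H]1O[C@@H](n2cnc3c(S)nccc32)C[C@@H]1O` gives 10%; compound 3 `OC[C@H]1OC(n2cnc3c(NCc4ccccc4)nccc32)[C@H](O)[C@@H]1O` gives 32%.

Compound 3 holds the highest of the three numbers, and its gaps to both other compounds lie beyond the scatter. From compound 1 to compound 2 one change is made, (sulfanyl in place of benzylamino on an aromatic carbon), and it gave a number 5 percentage points lower from compound 1 to compound 2 (within the scatter). Compound 4 `OC[C@H]1OC(n2cnc3c(S)nccc32)[C@H](O)[C@@H]1O` has not yet been measured; it arises from compound 3 by the same change, (sulfanyl in place of benzylamino on an aromatic carbon), placed on the core of compound 3. The difference between the two cores is not broken down here. Because a number 5 percentage points lower from compound 1 to compound 2 (within the scatter) stayed within the scatter, the step expected from the same change on compound 4 is a number 5 percentage points lower from compound 3 to compound 4 (within the scatter). In this assay compound 4 is therefore estimated at 27%, most likely between 12% and 42%.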

Compound 4, a percentage reported as inhibition, at one concentration (the size of the read-out at that concentration, not a potency): 6%
Beside the measured number, compound 4's estimate is 21 percentage points above it, outside the stated range (below it).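

On the second core, sulfanyl in place of benzylamino gave a number 26 percentage points lower from compound 3 to compound 4 (beyond the scatter). The size of this step therefore did not carry over from one core to the other in this assay: the same change on two cores in this assay, a number 5 percentage points lower (within the scatter) from compound 1 to compound 2 and a number 26 percentage points lower (beyond the scatter) from compound 3 to compound 4, 21 percentage points apart, beyond the scatter of two such steps

This shows that, for these two pairs, the effect of the change differs with the core, but it does not show which part of the difference between the cores matters, and two pairs set no general rule for the series.

The compounds shown leave open how other groups on that aromatic carbon, such as a plain amine, a hydroxyl group or a carboxylic acid, would behave on either core. They also leave open whether a longer chain carrying the same aromatic ring would keep the step seen with benzylamino.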